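The source may hold more compounds than are shown below. What is called first, only, known or untested is meant among the compounds shown, and "the series" means these compounds.

Compound 1, `CN(C(=O)NC(=O)c1ccc(C(F)(F)F)cc1)c1nc(C(F)(F)F)c(C(=O)N/N=C/c2cccc(C(F)(F)F)c2)s1`, gives 1.84 ug/mL in a functional assay on BCG823 cells (Homo sapiens) for inhibition, read by MTT assay, with a stated time of 72 h; a higher number here means a weaker inhibitor, a lower number a stronger inhibitor. Compound 2, `CN(C(=O)NC(=O)c1ccc(F)c(F)c1)c1nc(C(F)(F)F)c(C(=O)N/N=C/c2cccc(C(F)(F)F)c2)s1`, gives 4.46 ug/mL in this assay.

Compound 2 has the higher of the two numbers, and the step of a 2.4-fold higher number from compound 1 to compound 2 (0.38 log units; beyond the scatter) lies beyond the scatter. Compound 3, `CN(C(=O)NC(=O)c1cccc(C(F)(F)F)c1)c1nc(C(F)(F)F)c(C(=O)N/N=C/c2cccc(C(F)(F)F)c2)s1`, differs from compound 2 by 3-(trifluoromethyl)phenyl in place of 3,4-difluorophenyl on a carbonyl carbon. Within the data shown here, the only step that bears on it is a 2.4-fold higher number from compound 1 to compound 2 (0.38 log units; beyond the scatter), which shows a modest change when the trifluoromethyl-bearing phenyl was exchanged. With a trifluoromethylphenyl returning, compound 3 is expected to give a modestly lower number, a 1.7-fold lower number from compound 2 to compound 3 (0.23 log units; within the scatter), in this assay. Compound 3 is therefore estimated at 2.6 ug/mL, within 1.2 ug/mL to 5.5 ug/mL.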

Compound 3, half-maximal inhibitory concentration: 4.6 ug/mL
For compound 3 the middle estimate is 1.8-fold (0.25 log units) below the measured one; low and high end bracket the measured number.
By their numbers in this assay, from the lowest: compound 1; then compounds 2 and 3 (each within the scatter of the next).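

In this assay, 3-(trifluoromethyl)phenyl in place of 3,4-difluorophenyl on the carbonyl carbon gives a 1.0-fold higher number from compound 2 to compound 3 (0.01 log units; within the scatter), so the two groups are not told apart here. In contrast, 3-(trifluoromethyl)phenyl in place of 4-(trifluoromethyl)phenyl gives a 2.5-fold higher number from compound 1 to compound 3 (0.40 log units; beyond the scatter), so these two isomeric groups are not interchangeable at this position, and compound 1 keeps the lowest number of the three. Nothing available accounts for this difference. As far as these compounds go, it remains open how a phenyl bearing an amine or a carboxylic acid would behave here, and whether a plain unsubstituted phenyl would match compound 1 or compound 3.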